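This account rests on a few compounds, and the source may have more. Where it says the series, first, only, none or still open, it means among the compounds named here.

Compound 1 `CC(C)(C)C(=O)N1Cc2c(NC(=O)C3CCNCC3)n[nH]c2C1(C)C` gives 650 nM in a functional assay on A2780 cells (Homo sapiens) for antiproliferative activity, read by fluorescence, with a stated time of 72 h (on this read-out lower numbers stand for stronger inhibition and higher numbers for weaker inhibition), and compound 2 `CN1CCC(C(=O)N2Cc3c(NC(=O)c4ccsc4)n[nH]c3C2(C)C)CC1` gives 140 nM as the lower of these two numbers, with a gap beyond the scatter. Among the measured compounds shown here, compound 3 `CN1CCC(C(=O)N2Cc3c(NC(=O)c4cccc(F)c4)n[nH]c3C2(C)C)CC1` has no measurement yet. Against compound 2 it carries 3-fluorophenyl in place of thiophen-3-yl on a carbonyl carbon with 3-fluorophenyl in place of thiophen-3-yl on a carbonyl carbon. For the measured compounds named here, no measured pair shows this change, so no step beyond the scatter is expected in this assay and neither direction is favoured. The expected size is a 1.1-fold higher number from compound 2 to compound 3 (0.06 log units; within the scatter) on this estimate. Compound 3 is estimated at 160 nM with an expected range from 60 nM to 420 nM in this assay.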

Compound 3, half-maximal inhibitory concentration: 200 nM
The estimate for compound 3 lay 1.3-fold (0.10 log units) below the measured number, and the stated range covers the measured number.
By their numbers in this assay, from the lowest: compounds 2 and 3 (each within the scatter of the next); then compound 1.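

In this assay, 3-fluorophenyl in place of thiophen-3-yl on a carbonyl carbon whose other neighbour is an amide-type nitrogen gives a 1.4-fold higher number from compound 2 to compound 3 (0.15 log units; within the scatter) and so does not separate the two rings at this position. This is the only single-place step shown, so the reading rests on one pair. Nothing measured here bears on the reason for this result. Still open, as far as these compounds go, is how phenyl without fluorine, a piperidine or a longer alkyl chain would read on this carbonyl carbon.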